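Replacing (4-methylphenyl)amino with 4-methylphenoxy on a carbonyl carbon

This account rests on a few compounds, and the source may have more. Where it says the series, first, only, none or still open, it means among the compounds named here.

In a functional assay on MDA-MB-231 cells (Homo sapiens) for inhibition, read by MTT assay, with a stated time of 72 h (on this read-out lower numbers stand for stronger inhibition and higher numbers for weaker inhibition), compound 1 (`COC(=O)c1ccc(-n2cc(CCCC(=O)Nc3ccc(C)cc3)nn2)cc1`) gives 9700 nM as its measured figure. Going by the values given here, the only other measured compound is compound 2 (`COC(=O)c1ccc(-n2cc(CCCC(=S)Nc3ccc(C)cc3)nn2)cc1`) at 8100 nM in the same test. These two values lie within the scatter of each other, so compound 1 stands level with compound 2 on the numbers available. Compound 3 (`COC(=O)c1ccc(-n2cc(CCCC(=O)Oc3ccc(C)cc3)nn2)cc1`) has not yet been measured. It differs from compound 1 in one place, with 4-methylphenoxy in place of (4-methylphenyl)amino on a carbonyl carbon and the rest of the structure shared. Among the compounds with values here, no measured pair tests this change, so the expectation starts from compound 1 at 9700 nM and foresees no step beyond the scatter in this assay in either direction. The estimated step of a 1.0-fold higher number from compound 1 to compound 3 (0.01 log units; within the scatter) is expected to be small. Compound 3 is estimated at 10000 nM, with a range of 4000 nM to 25000 nM expected once it is tested.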

Compound 3, half-maximal inhibitory concentration: 55100 nM
The estimate for compound 3 lay 5.5-fold (0.74 log units) below the measured number; the measured number lies above the stated range.
By their numbers in this assay, from the lowest: compounds 2 and 1 (each within the scatter of the next); then compound 3.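

In this assay, putting 4-methylphenoxy in place of (4-methylphenyl)amino on a carbonyl carbon gives a 5.7-fold higher number from compound 1 to compound 3 (0.75 log units; beyond the scatter), so the number at this position does respond to the atom that joins the carbonyl carbon to the 4-methylphenyl ring. Compound 1 and compound 2 had stood level, so the earlier pair, which differs at the carbonyl itself, gave no sign that this part of the chain could move the number; here nitrogen gives way to oxygen and the amide hydrogen is lost. No measurement at hand says what lies behind this rise.

The compounds shown leave open whether the amide hydrogen itself matters, which a tertiary amide with a methyl group on that nitrogen would test. They also leave open whether a methylene group in place of that nitrogen would stand with compound 1 or with compound 3.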